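Aryl swap at the ether-bearing side chain

This account rests on a few compounds, and the source may have more. Where it says the series, first, only, none or still open, it means among the compounds named here.

Measured compounds in an assay on isolated protein for activation of cGMP-dependent protein kinase 1 (Homo sapiens), read by ADP-Glo, with stated times of 30 min and 2 h, in the presence of a further agent that is not named here; on this read-out lower numbers stand for an effect already at smaller amounts and higher numbers for an effect only at larger amounts of compound:
compound 1 `Cc1cc(C(=O)O)ccc1CN1CCC[C@H](O[C@H](CO)c2cc(F)cc(F)c2)[C@@H]1c1ccccc1` gives 1500 nM
compound 2 `Cc1cc(C(=O)O)ccc1CN1CCC[C@H](O[C@H](CO)c2cc(Cl)nc(Cl)c2)[C@@H]1c1ccccc1` gives 2400 nM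
compound 3 `Cc1cc(C(=O)O)ccc1CN1CCC[C@H](O[C@H](CO)c2ccnc(Cl)c2)[C@@H]1c1ccccc1` gives 50000 nM

Compound 3 carries the highest number of the three. Its nearest neighbour is compound 2, with a 21-fold higher number from compound 2 to compound 3 (1.32 log units; beyond the scatter), and the gap to compound 1 is wider still, a 33-fold higher number from compound 1 to compound 3 (1.52 log units; beyond the scatter); both steps lie beyond the scatter. Compound 1 and compound 2 sit within the scatter of each other, a 1.6-fold higher number from compound 1 to compound 2 (0.20 log units; within the scatter).

The next compound, compound 4 `Cc1cc(C(=O)O)ccc1CN1CCC[C@H](O[C@H](CO)c2cccc(Cl)c2)[C@@H]1c1ccccc1`, differs from compound 3 in one place: 3-chlorophenyl in place of 2-chloropyridin-4-yl on a saturated chain carbon bound to an oxygen on a saturated carbon and a saturated chain carbon. Within the data shown here, two measured steps bear on this change. The step of a 33-fold higher number from compound 1 to compound 3 (1.52 log units; beyond the scatter) shows what happens when a carbon-only ring is exchanged for the 2-chloropyridin-4-yl ring at this position, and the step of a 21-fold higher number from compound 2 to compound 3 (1.32 log units; beyond the scatter) shows the loss of one chloro on the aromatic ring. Compound 4 returns to a carbon-only ring while keeping one chloro, so a large step down from compound 3 is expected in this assay, roughly retracing a 33-fold higher number from compound 1 to compound 3 (1.52 log units; beyond the scatter), though compound 1 carries two halogens and compound 4 only one. The step expected is a 17-fold lower number from compound 3 to compound 4 (1.22 log units; beyond the scatter). For compound 4 the estimate is 3000 nM, with a range from 800 nM to 15000 nM.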

Compound 4, half-maximal effective concentration: 1300 nM
For compound 4 the middle estimate is 2.3-fold (0.36 log units) above the measured one; the measured number falls inside the stated range.
By their numbers in this assay, from the lowest: compounds 4, 1 and 2 (each within the scatter of the next); then compound 3.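

In this assay, among these compounds, the step of a 38-fold lower number from compound 3 to compound 4 (1.59 log units; beyond the scatter) is the sharpest reading of this position so far: 3-chlorophenyl and 2-chloropyridin-4-yl have the same heavy-atom count and differ in a ring carbon against a ring nitrogen, so the high number of compound 3 goes with the pyridine ring carrying one chloro and not with the single chloro as such. A carbon-only ring with one chloro holds the level of the other two rings, since both a 1.2-fold lower number from compound 1 to compound 4 (0.06 log units; within the scatter) and a 1.8-fold lower number from compound 2 to compound 4 (0.27 log units; within the scatter) stay within the scatter, and 3-chlorophenyl, 3,5-difluorophenyl and 2,6-dichloropyridin-4-yl cannot be told apart here; a ring nitrogen alone therefore does not go with a high number, and compound 2 stands against any such rule. Nothing measured here explains why the two pyridine rings part so widely.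

Still open, on these data alone, is whether a group other than chloro as the second substituent on the 2-chloropyridin-4-yl ring, such as methoxy or an amine, brings the number back as the second chloro of compound 2 does. Equally open, as far as these compounds go, is whether a nitrile or a carboxylic acid in place of the chloro of 3-chlorophenyl would hold the level of compound 4.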